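Replacing the Methoxy Group of Compound 2

The source may report more compounds than this note shows. Statements on the series, on what has been measured and on what is new or still open speak of the compounds shown alone.

Compound 1 `CC(O)(c1ccc(-c2ccc(S(=O)(=O)c3ccc(N)nc3)cc2)cc1)C(F)(F)F` and compound 2 `COc1cc(C(O)(C(F)(F)F)C(F)(F)F)cnc1-c1ccc(S(=O)(=O)c2ccc(N)nc2)cc1` have both been tested in an ADME assay (liver) for metabolic stability, with Liver microsome (Rattus norvegicus) as the target, using microsomes and NADPH, with a stated time of 30 min, at 37 degrees C, tested at 1 uM; on this read-out lower numbers stand for slow clearance and higher numbers for fast clearance. Compound 1 gives < 14 mL.min-1.g-1, which is a limit of the assay and not a number. Compound 2 gives < 14 mL.min-1.g-1, which is also a limit and not a number. Compound 2 therefore has no exact reading, and what the two compounds show together is the limit of < 14 mL.min-1.g-1 in this assay, at which 2 of the 2 values shown sit. Among the compounds with values here, no measured step links two compounds that differ in one place, so the next change has to be judged without a direct guide.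

That change leads to compound 3 `Nc1ccc(S(=O)(=O)c2ccc(-c3ncc(C(O)(C(F)(F)F)C(F)(F)F)cc3C#CCO)cc2)cn1`, in which 3-hydroxyprop-1-yn-1-yl stands in place of methoxy on an aromatic carbon, ortho to a large group and two atoms from the ring nitrogen (3-hydroxyprop-1-yn-1-yl in place of methoxy on an aromatic carbon). The expected move a number no lower from compound 2 to compound 3 (the limit leaves the size open) is estimated to be none beyond the usual scatter, with no firm direction. The reading may well turn out to be only a limit once more. For compound 3 the expected value is 14 mL.min-1.g-1, with an estimated range of 7 mL.min-1.g-1 to 32 mL.min-1.g-1.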

Compound 3, intrinsic clearance in microsomes: 36 mL.min-1.g-1
Compound 3: the middle estimate sits 2.6-fold (0.41 log units) below what was measured; the measured number lies above the stated range.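

Until now, the two compounds shown sat at the assay limit, so they gave no sign of whether this ring position could affect clearance at all. In this assay, putting 3-hydroxyprop-1-yn-1-yl in place of methoxy gives an at least 2.5-fold higher number from compound 2 to compound 3 (0.41 log units; beyond the scatter), which shows that this aromatic carbon, ortho to a large group and two atoms from the ring nitrogen, is sensitive to the group it carries, and that this particular replacement moves the read-out towards faster clearance; the size of the step is only a lower bound, since the reading for compound 2 is a limit and not a number. Compound 3 is also the only compound here with a reading that is an actual number rather than a limit, which sets it apart from the other two: the limit of < 14 mL.min-1.g-1 in this assay, at which 2 of the 3 values shown sit.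

The change brings in a longer chain, a triple bond and a hydrogen-bond donor all at once, and the compounds shown cannot tell which of these matters. As far as these compounds go, a plain prop-1-yn-1-yl group without the hydroxyl, or a saturated 3-hydroxypropyl chain at the same place, would separate these features, while the true distance between compound 2 and compound 3 also remains unknown.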